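Aryl swap on the shared core of compound 1

The compounds below may be only part of what the source reports. "The series", "measured", "known", "first", "only" and "open" are said of these compounds alone.

Measured so far:
compound 1 `Oc1cccc(-c2cc(-c3cccs3)cc(-c3cccc(O)c3)n2)c1` — 1630 nM
compound 2 `Oc1ccc(-c2cc(-c3cccs3)cc(-c3cccc(O)c3)n2)cc1` — 1890 nM

In a functional assay on DU-145 cells (Homo sapiens) for cytotoxicity, read by CCK-8 assay (a higher number here means a weaker inhibitor, a lower number a stronger inhibitor), compound 1 gives 1630 nM. Compound 2 gives 1890 nM in this assay. Going by the values given here, the only measured step, a 1.2-fold higher number from compound 1 to compound 2 (0.06 log units; within the scatter), lies within the scatter, so the two numbers cannot be told apart and compound 1 stands level with compound 2.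

Compound 3 `Oc1cccc(-c2cc(-c3cccnc3)cc(-c3cccc(O)c3)n2)c1` differs from compound 1 by pyridin-3-yl in place of thiophen-2-yl on an aromatic carbon. Among the compounds with values here, no measured step touches this position; the step from compound 1 to compound 2 concerns a hydroxyphenyl group elsewhere on the shared core and bears on it only as a sign that one aryl exchange on this core left this assay unchanged. On that basis the expected step is a 1.1-fold higher number from compound 1 to compound 3 (0.04 log units; within the scatter), which is none beyond the scatter, with a wide range for the untested position. Compound 3 is therefore estimated at 1800 nM, between 700 nM and 4500 nM.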

Compound 3, half-maximal inhibitory concentration: > 50000 nM
Compound 3: no number, only a limit (the forecaster's own chance of this, stated with the estimate: 5%); middle value at least 27-fold (1.44 log units) away from the limit.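

The position opposite the ring nitrogen is far less tolerant than the earlier pair suggested: pyridin-3-yl in place of thiophen-2-yl gives an at least 30-fold higher number from compound 1 to compound 3 (1.48 log units; beyond the scatter) in this assay. Going by these compounds, the reading for compound 3 is a limit of the assay and not a number, so the full size of this step stays unknown: the limit of > 50000 nM in this assay, at which 1 of the 3 values shown sits. On the shared core, the exchange of hydroxyphenyl groups gives a 1.2-fold higher number from compound 1 to compound 2 (0.06 log units; within the scatter), whereas the exchange at this position separates the two compounds clearly.

On these data alone, it remains open whether the step follows the departure of thiophen-2-yl or the arrival of pyridin-3-yl; plain phenyl, furan-2-yl or pyridin-4-yl at this position would separate the two readings. Also open, as far as these compounds go, is whether an amine or a carboxylic acid on the thiophen-2-yl ring would be tolerated.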